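The source may report more compounds than this note shows. Statements on the series, on what has been measured and on what is new or still open speak of the compounds shown alone.

Compound 3 `CCCCCCCCCCCCCCCC(=O)OC[C@H](CSCC[C@H](N)C(=O)N[C@@H](CO)C(=O)O)OC(=O)CCCCCCCCCCCCCCC` is one of three dipalmitoylglycerol thioethers measured in a functional assay on HEK293 cells for agonist activity at Toll-like receptor 2 (Homo sapiens), read by spectrophotometry, with a stated time of 12 h; a lower number here means that less compound is needed, a higher number that more compound is needed for the effect. In this assay compound 3 gives only a limit, > 1000 nM, not a number. Compound 1 `CCCCCCCCCCCCCCCC(=O)OC[C@H](CSC[C@H](N)C(=O)NCC(=O)OC(C)C)OC(=O)CCCCCCCCCCCCCCC` gives 0.45 nM in this assay. Compound 2 `CCCCCCCCCCCCCCCC(=O)OC[C@H](CSC(C)(C)[C@@H](N)C(=O)N[C@@H](CO)C(=O)OC)OC(=O)CCCCCCCCCCCCCCC` likewise reaches only the limit of this assay at > 1000 nM. Among the compounds with values here, the one step that joins two of these, an at least 2200-fold higher number from compound 1 to compound 3 (3.34 log units; beyond the scatter), is the only measured change in this set, and compound 3 sits at the weak end of it, at the limit of > 1000 nM in this assay, at which 2 of the 3 values shown sit.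

Compound 4 `CCCCCCCCCCCCCCCC(=O)OC[C@H](CSCCC(=O)N[C@@H](CO)C(=O)OC)OC(=O)CCCCCCCCCCCCCCC` differs from compound 3 by (2-hydroxy-1-(methoxycarbonyl)ethyl)carbamoyl in place of amino((1-carboxy-2-hydroxyethyl)carbamoyl)methyl on a saturated chain carbon, two bonds along the chain from a sulfur. Within the data shown here, no measured step follows this exact change; the nearest neighbour is compound 2, which keeps an amino group but carries a methyl ester, and it too sits at the limit. The large step from compound 1 to compound 3 shows how sharply this assay answers changes in the head group, but it does not say in which direction the present change would move the number. With compound 3 already at the limit and nothing pointing upward, compound 4 is expected to stay at or beyond that limit, a step that the limit leaves unreadable from compound 3 to compound 4. The estimate for compound 4 in this assay is 5000 nM, with a range from 800 nM to 50000 nM.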

Compound 4, half-maximal effective concentration: > 1000 nM
Compound 4: only a limit was reported; the forecaster's own chance of this, stated with the estimate: 85%; the middle value lies beyond the limit too.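

In this assay compound 4 gives > 1000 nM, which is a limit and not a number. Compound 3 also gives only a limit, so the step between them cannot be read; what the result does show is that (2-hydroxy-1-(methoxycarbonyl)ethyl)carbamoyl in place of amino((1-carboxy-2-hydroxyethyl)carbamoyl)methyl, on a saturated chain carbon, two bonds along the chain from a sulfur, does not bring the compound back to a measurable value. Measured against the one compound with a number, ((2-hydroxy-1-(methoxycarbonyl)ethyl)carbamoyl)methyl in place of amino(((isopropoxycarbonyl)methyl)carbamoyl)methyl gives an at least 2200-fold higher number from compound 1 to compound 4 (3.34 log units; beyond the scatter), and compound 4 joins the group at the assay's limit: the limit of > 1000 nM in this assay, at which 3 of the 4 values shown sit.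

From the compounds shown here alone, how far compound 3 and compound 4 lie beyond that limit, and whether either differs from the other, remains unknown. Going by these compounds, it also remains open whether an amine on the chain of compound 4, or an isopropyl ester in place of its methyl ester, would return a measurable value in this assay.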